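Compound 3 to compound 4: replacing the bromine

The source may hold more compounds than are shown below. What is called first, only, known or untested is meant among the compounds shown, and "the series" means these compounds.

In a functional assay on HepG2 cells (Homo sapiens) for antiproliferative activity, read by MTT assay, with a stated time of 48 h (on this read-out lower numbers stand for stronger inhibition and higher numbers for weaker inhibition), compound 1 (`COc1ccc(N(C)c2ccnc(Cl)n2)cc1`) gives 2120 nM and compound 2 (`COc1ccc(N(C)c2ccnc(Cl)n2)cc1Cl`) gives 2630 nM as values that sit within the scatter of each other, the step being a 1.2-fold higher number from compound 1 to compound 2 (0.09 log units; within the scatter) and no more. Compound 3 (`COc1ccc(N(C)c2ccnc(Cl)n2)cc1OCCCCBr`) stands lowest of the three at 168 nM and is the most potent so far. Two large steps reach it, a 13-fold lower number from compound 1 to compound 3 (1.10 log units; beyond the scatter) and a 16-fold lower number from compound 2 to compound 3 (1.19 log units; beyond the scatter), both beyond the scatter and both bringing in the 4-bromobutoxy group.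

Compound 4 (`COc1ccc(N(C)c2ccnc(Cl)n2)cc1OCCCC[Se]C#N`) keeps everything else in place. The change is a group of 3 heavy atoms (1 carbon, 1 nitrogen, 1 selenium; no ring) in place of one bromine atom, on a saturated chain carbon, four bonds along the chain from an oxygen on an aromatic ring on a saturated chain carbon, four bonds along the chain from an oxygen on an aromatic ring. Going by the values given here, no measured step alters the end of this chain, so the guidance is indirect. The one relevant observation is that introducing the chain has already moved the number strongly, as a 13-fold lower number from compound 1 to compound 3 (1.10 log units; beyond the scatter) shows, so a further change there is expected to register. The step expected is a 2.4-fold lower number from compound 3 to compound 4 (0.38 log units; beyond the scatter) as a moderate one toward lower numbers, with its size poorly constrained. Compound 4 is estimated at 70 nM with an expected range from 15 nM to 300 nM as the working figure.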

Compound 4, half-maximal inhibitory concentration: > 10000 nM
Compound 4 ended at the assay's limit; the forecaster's own chance of this, stated with the estimate: 3%; middle value at least 140-fold (2.15 log units) away from the limit.
By their numbers in this assay, from the lowest: compound 3; then compounds 1 and 2 (each within the scatter of the next). At a limit, above all of these: compound 4.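

In this assay compound 4 gives > 10000 nM, which is a limit of the assay and not a number: the limit of > 10000 nM in this assay, at which 1 of the 4 values shown sits.

The end of the chain therefore counts as well as the chain itself: at this place, on a saturated chain carbon, four bonds along the chain from an oxygen on an aromatic ring, exchanging the bromine atom for the group of carbon, nitrogen and selenium gives an at least 59-fold higher number from compound 3 to compound 4 (1.77 log units; beyond the scatter). The chain alone does not secure the low number of compound 3, as the series without the chain also stands lower, with an at least 4.7-fold higher number from compound 1 to compound 4 (0.67 log units; beyond the scatter) and an at least 3.8-fold higher number from compound 2 to compound 4 (0.58 log units; beyond the scatter), so the gain seen on introducing the 4-bromobutoxy group depends here on the bromine end.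

The compounds shown do not tell whether the bromine atom is specifically required, or whether another chain end, such as a chlorine atom, a hydroxyl, an amine or a carboxylic acid, would keep the number near that of compound 3. Also open, from the compounds shown here alone, is how a shorter or longer chain carrying the same bromine end would read, and how far beyond the limit compound 4 truly lies.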